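Replacing piperidinyl with methoxyazetidinyl on the amide carbonyl

The compounds below may be only part of what the source reports. "The series", "measured", "known", "first", "only" and "open" are said of these compounds alone.

Compound 1 `O=C(Nc1sc2c(c1C(=O)N1CCCCC1)CCOC2)c1ccccc1C(F)(F)F` carries a (piperidin-1-yl)carbonyl on its shared core and a trifluoromethyl group on the benzamide ring. Among the compounds with values here, in an in vitro ADME assay on microsomes from liver (Mus musculus) for metabolic stability (on this read-out lower numbers stand for a shorter-lived compound and higher numbers for a longer-lived compound), compound 1 gives 0.258 h, the higher of the two numbers measured so far. Compound 2 `O=C(Nc1sc2c(c1C(=O)N1CCCCC1)CCOC2)c1ccccc1OC(F)(F)F`, which differs only in a trifluoromethoxy in place of trifluoromethyl on an aromatic carbon, gives in this assay 0.167 h; the step of a 1.5-fold lower number from compound 1 to compound 2 (0.19 log units; within the scatter) lies within the scatter, so the two compounds cannot be ordered.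

Compound 3 `COC1CN(C(=O)c2c(NC(=O)c3ccccc3C(F)(F)F)sc3c2CCOC3)C1` changes a different part of the molecule: 3-methoxyazetidin-1-yl in place of piperidin-1-yl on a carbonyl carbon. Within the data shown here, the only measured step concerns the aromatic substituent and says nothing about the amide side, so no measured step bears on this change and there is no basis for expecting a shift in either direction. Compound 3 is therefore estimated to sit near compound 1, with a step of a 1.1-fold higher number from compound 1 to compound 3 (0.04 log units; within the scatter) that does not exceed the scatter, giving an expected half-life for compound 3 of 0.28 h, with a range from 0.12 h to 0.7 h.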

Compound 3, half-life: 0.622 h
Beside the measured number, compound 3's estimate is 2.2-fold (0.35 log units) below it; low and high end bracket the measured number.
By their numbers in this assay, from the lowest: compounds 2 and 1 (each within the scatter of the next); then compound 3.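

With 3-methoxyazetidin-1-yl in place of piperidin-1-yl on a carbonyl carbon, this assay shows a 2.4-fold higher number from compound 1 to compound 3 (0.38 log units; beyond the scatter). Within the data shown here, this makes the amide side the first place where a single change moves the half-life beyond the scatter, which the one earlier step, on the benzamide ring, did not do. The exchange keeps the heavy-atom count but replaces a six-membered ring with a four-membered one and adds a methoxy group with one hydrogen-bond acceptor, and no measurement at hand explains why the number rises.

Ring size and the methoxy group change together in this single step, so the compounds shown cannot separate their contributions, and it remains open whether a plain azetidin-1-yl or a morpholine amide would give a similar number. As far as these compounds go, it is also open whether the same amide change would give a similar step on the trifluoromethoxy benzamide of compound 2.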